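Forecasting a chloro analogue of compound 1

The source may report more compounds than this note shows. Statements on the series, on what has been measured and on what is new or still open speak of the compounds shown alone.

compound 1, `COc1ccc(OC)c(/C=C/C(=O)N/N=C/c2ccccc2)c1`, "not determined" (no result reported)
compound 2, `COc1ccc(OC)c(/C=C/c2nnc(Nc3ccc(Cl)cc3)o2)c1`, > 100000 nM

Compound 1 `COc1ccc(OC)c(/C=C/C(=O)N/N=C/c2ccccc2)c1` stands without a number of its own: in a functional assay on SR cells (Homo sapiens) for antiproliferative activity, read by sulforhodamine B assay, with a stated time of 48 h (on this read-out higher numbers stand for lower toxicity in this test and lower numbers for higher toxicity in this test), compound 1 is recorded as "not determined" (no result reported). Among the compounds with values here, compound 2 `COc1ccc(OC)c(/C=C/c2nnc(Nc3ccc(Cl)cc3)o2)c1` is the only compound with a reported result, and that result is a limit of the assay rather than a number: in this assay compound 2 gives > 100000 nM. Within the data shown here, this is the limit of > 100000 nM in this assay, at which 1 of the 2 values shown sits, and with one result undetermined and the other a limit, no step between measured compounds can be drawn.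

Compound 3 `COc1ccc(OC)c(/C=C/C(=O)N/N=C/c2ccc(Cl)cc2)c1` differs from compound 1 in one place: chloro in place of hydrogen on an aromatic carbon. Among the measured compounds shown here, with no measured step to set a size or direction, the expectation in this assay for the step from compound 1 to compound 3 is none beyond the scatter. Compound 3 is then expected to fall near 30000 nM, in a range from 3000 nM to 100000 nM.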

Compound 3, concentration lethal to 50% of the cells: > 100000 nM
Compound 3: only a limit was reported; the forecaster's own chance of this, stated with the estimate: 40%; at least 3.3-fold (0.52 log units) between middle value and limit.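

In this assay compound 3 gives > 100000 nM, a limit and not a number. Within the data shown here, compound 1 is recorded as "not determined" (no result reported), so no step between compound 1 and compound 3 can be read. The compounds shown leave open how phenyl and 4-chlorophenyl compare in this assay, with results resting on: the limit of > 100000 nM in this assay, at which 2 of the 3 values shown sit.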